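The source may report more compounds than this note shows. Statements on the series, on what has been measured and on what is new or still open speak of the compounds shown alone.

In an assay on isolated protein for agonist activity at Bile acid receptor (Homo sapiens), read by FRET (on this read-out lower numbers stand for smaller maximal responses and higher numbers for larger maximal responses), compound 1 `O=C(O)c1cccc([C@H]2C[C@@H](c3ccc(OCc4c(-c5c(Cl)cccc5Cl)noc4C4CC4)cc3Cl)C2)c1` gives 99%, compound 2 `CCO[C@]1(c2ccc(OCc3c(-c4c(Cl)cccc4Cl)noc3C3CC3)cc2Cl)C[C@H](c2cccc(C(=O)O)c2)C1` gives 94%, and compound 3 `O=C(O)c1cccc([C@H]2C[C@](OCCO)(c3ccc(OCc4c(-c5c(Cl)cccc5Cl)noc4C4CC4)cc3Cl)C2)c1` gives 97%. On the numbers alone compound 3 stands second of the three, yet both a number 2 percentage points lower from compound 1 to compound 3 (within the scatter) and a number 3 percentage points higher from compound 2 to compound 3 (within the scatter) sit within the scatter, so the three values cannot be told apart. Compound 4 `CO[C@]1(c2ccc(OCc3c(-c4c(Cl)cccc4Cl)noc3C3CC3)cc2Cl)C[C@H](c2cccc(C(=O)O)c2)C1` differs from compound 3 by hydrogen in place of hydroxymethyl on a saturated chain carbon bound to an oxygen on a saturated carbon. The closest guide is the reverse of this change, a number 3 percentage points higher from compound 2 to compound 3 (within the scatter), which stayed within the scatter; a number 5 percentage points lower from compound 1 to compound 2 (within the scatter) did likewise. Therefore no step beyond the scatter is expected in this assay, and the expected step is a number 2 percentage points lower from compound 3 to compound 4 (within the scatter). Compound 4 is estimated at 95%, with a likely range from 85% to 105%.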

Compound 4, largest response reached (reported as efficacy), in percent of the reference or control that the assay uses: 93%
For compound 4 the middle estimate is 2 percentage points above the measured one, within the range that was stated.
By their numbers in this assay, from the lowest: compounds 4, 2, 3 and 1 (each within the scatter of the next).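

In this assay the steps of a number 6 percentage points lower from compound 1 to compound 4 (within the scatter) and a number 1 percentage points lower from compound 2 to compound 4 (within the scatter) and a number 4 percentage points lower from compound 3 to compound 4 (within the scatter) place methoxy on this saturated ring carbon alongside hydrogen, ethoxy and 2-hydroxyethoxy. Removing the hydroxymethyl therefore gives no step beyond the scatter, and the four compounds cannot be told apart on this read-out. Nothing available explains this result. Still open, as far as these compounds go, is whether an amine or a carboxylic acid at the end of this chain, or a chain longer than 2-hydroxyethoxy, would also stay within the scatter.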